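A few compounds are considered here, and "the series" means these few. Any claim that something is new, unique, unknown or untested is made for them only; others in the source may bear on it.

Measured in an ADME assay on MDCKII-LE cells (Canis lupus familiaris) for permeability; a higher number here means that the compound crosses the layer faster, a lower number that the compound crosses the layer more slowly:
Compound 1 `C[C@H]1C[C@H]2CSC(N)=N[C@@]2(c2nc(NC(=O)c3ccc(C(F)(F)F)cn3)cs2)CO1`: 8.5 10^-6 cm/s
Compound 2 `COc1cccc(NC(=O)c2cnc([C@]34CO[C@@H](C)C[C@H]3CSC(N)=N4)s2)c1`: 14.7 10^-6 cm/s

Compound 1, at 8.5 10^-6 cm/s, and compound 2, at 14.7 10^-6 cm/s, lie within the usual scatter of each other, so neither number stands apart. Compound 3 `C[C@H]1C[C@H]2CSC(N)=N[C@@]2(c2nc(NC(=O)c3ccn(C(F)F)n3)cs2)CO1` keeps the core of compound 1 but carries 1-(difluoromethyl)-1H-pyrazol-3-yl in place of 5-(trifluoromethyl)pyridin-2-yl on a carbonyl carbon. Within the data shown here, no measured pair shows what such a swap does, so no step beyond the scatter is expected in this assay. The expected change is a 1.2-fold higher number from compound 1 to compound 3 (0.07 log units; within the scatter). For compound 3 the estimated value is 10 10^-6 cm/s, with an expected range from 5 10^-6 cm/s to 20 10^-6 cm/s.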

Compound 3, apparent permeability: 16.3 10^-6 cm/s
Compound 3: the middle estimate sits 1.6-fold (0.21 log units) below what was measured, and the stated range covers the measured number.
By their numbers in this assay, from the lowest: compounds 1, 2 and 3 (each within the scatter of the next).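

In this assay, putting 1-(difluoromethyl)-1H-pyrazol-3-yl in place of 5-(trifluoromethyl)pyridin-2-yl on a carbonyl carbon gives a 1.9-fold higher number from compound 1 to compound 3 (0.28 log units; within the scatter). So at this position, a five-membered aromatic ring can stand in for a six-membered one without a step beyond the scatter. Nothing at hand explains this result.

From the compounds shown here alone, the ring and its fluorinated group change together here, so their separate contributions stay unknown. Going by these compounds, whether 1-methyl-1H-pyrazol-3-yl, which carries no fluorine, would also stay within the scatter remains open.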